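A few compounds are considered here, and "the series" means these few. Any claim that something is new, unique, unknown or untested is made for them only; others in the source may bear on it.

Measured so far in an in vitro assay on P815B cells for inhibition of Indoleamine 2,3-dioxygenase 1 (Mus musculus), tested at 20 uM; a higher number here means more inhibition at the concentration tested (going by the name of the read-out), a lower number less inhibition:

compound 1, `O=C(Cc1cccnc1)c1cc2ccccc2[nH]1` — 13%
compound 2, `CC(C(=O)c1cc2ccccc2[nH]1)c1cccnc1` — "not active" (no number reported)
compound 3, `O=C(Cc1ccccn1)c1cc2ccccc2[nH]1` — 10%

Compound 1 stands highest of the two numbers reported in this assay. Its nearest neighbour is compound 3, with a number 3 percentage points lower from compound 1 to compound 3 (within the scatter), a step within the scatter, so the two cannot be put in order; this step replaces pyridin-3-yl with pyridin-2-yl on a saturated chain carbon bound to a carbonyl carbon. Among the measured compounds shown here, compound 2 carries a methyl on that same chain carbon and is reported only as not active, without a number, so no sized step from it is available.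

The next compound, compound 4, `O=C(Cc1cccnc1)c1cc2cc([N+](=O)[O-])ccc2[nH]1`, keeps the chain and pyridin-3-yl of compound 1 and alters the shared core instead: nitro in place of hydrogen on an aromatic carbon. For the measured compounds named here, no measured step touches the core of compound 1 at all; the single sized step, from compound 1 to compound 3, concerns the pyridyl and is within the scatter, so it gives no guidance on a nitro on the aromatic carbon. With nothing to lean on, the expectation for compound 4 is a step of about a number 2 percentage points higher from compound 1 to compound 4 (within the scatter), that is no change beyond the scatter, held loosely. Compound 4 is therefore estimated at 15%, with a range from 0% to 35%.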

Compound 4, a percentage reported as inhibition, at one concentration (the size of the read-out at that concentration, not a potency): "not active" (no number reported)
For compound 4 the study gives words and no number; no gap can be computed for the estimate.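

Among the compounds shown here, compound 4 is reported in words only, like compound 2, so no sized step from compound 1 to compound 4 can be read. Nothing shown bears on the reason for this result. The compounds shown leave open how large any change from hydrogen to nitro on the shared core is, and how compound 2 and compound 4 rank against each other.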